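This account rests on a few compounds, and the source may have more. Where it says the series, first, only, none or still open, it means among the compounds named here.

Of the compounds shown here, three have been measured so far in a functional assay on HEK293 cells for agonist activity at D(4) dopamine receptor (Homo sapiens), read by FLIPR; a lower number here means that less compound is needed, a higher number that more compound is needed for the effect. Compound 1 `CCc1cccc(NC(=O)CN2CCC(c3cccc[n+]3[O-])CC2)c1` gives 95 nM in this assay, the lowest of the three numbers. Compound 3 `Cc1ccc(Cl)c(NC(=O)CN2CCC(c3cccc[n+]3[O-])CC2)c1Cl` gives 346 nM, and compound 2 `O=C(NCN1CCC(c2cccc[n+]2[O-])CC1)c1cnccc1Cl` gives 1290 nM; both of these differences from compound 1 lie beyond the scatter, so compound 1 stands clearly as the most potent of the three. Going by the values given here, none of the measured compounds differs from another in a single place, so no directly comparable step is available for guidance.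

Compound 4 `O=C(CN1CCC(c2cccc[n+]2[O-])CC1)Nc1cc(Cl)cc(Cl)c1` is the next compound to be measured. It differs from compound 1 in one place: 3,5-dichlorophenyl in place of 3-ethylphenyl on an amide-type nitrogen. The two groups are of the same size in heavy atoms and carry no donors or acceptors, and compound 3, which also carries two chlorines on its anilide ring, gives a number that is higher than that of compound 1 but within the same order of magnitude. On that basis a step from compound 1 to compound 4 that is modest and towards a higher number is expected, a 2.1-fold higher number from compound 1 to compound 4 (0.32 log units; beyond the scatter), though a result within the scatter would not be surprising. Compound 4 is estimated at 200 nM in this assay, with a likely range from 60 nM to 650 nM.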

Compound 4, half-maximal effective concentration: 160 nM
For compound 4 the middle estimate is 1.3-fold (0.10 log units) above the measured one; measured number inside the range.
By their numbers in this assay, from the lowest: compounds 1 and 4 (each within the scatter of the next); then compound 3; then compound 2.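

In this assay, placing 3,5-dichlorophenyl instead of 3-ethylphenyl on the amide-type nitrogen gives a 1.7-fold higher number from compound 1 to compound 4 (0.23 log units; within the scatter), so the two groups cannot be told apart in this test. Going by these compounds alone, this is the first comparison in the set where only one place changes, and it shows that the ethyl group is not needed at this position to keep the number close to that of compound 1: a ring carrying two chlorines serves as well. Nothing measured here explains why these two groups give such similar results.

On these data alone, both groups are carbon-only aromatic rings of the same heavy-atom count with no hydrogen-bond donors or acceptors, so it remains open how this position would respond to a ring bearing an amine or a carboxylic acid, or to a saturated ring such as cyclohexyl. As far as these compounds go, it is also open what a plain phenyl ring or one with a single chlorine would give, and such a compound would show whether these substituents matter at all at this position.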